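The source may hold more compounds than are shown below. What is called first, only, known or untested is meant among the compounds shown, and "the series" means these compounds.

Working notes on the series in a functional assay on CCRF-CEM cells for agonist activity at C-X-C chemokine receptor type 4 (Homo sapiens), read by calcium flux, with a stated time of 25 min; on this read-out lower numbers stand for an effect already at smaller amounts and higher numbers for an effect only at larger amounts of compound.

Compound 1 `CN(C[C@H]1Cc2c(cccc2N2CCN(Cc3ccccn3)CC2)CN1)[C@H]1CCCc2cccnc21` sits at the assay limit: in this assay compound 1 gives > 30000 nM, a limit rather than a number. Compound 2 `CN(C[C@H]1Cc2c(cccc2N2CCN(C3CC3)CC2)CN1)[C@H]1CCCc2cccnc21` is likewise reported only as a limit, with > 30000 nM in this assay. Going by the values given here, the one measured step, a step that the two limits leave unreadable from compound 1 to compound 2, is therefore unreadable in size; both values lie at the same limit (the limit of > 30000 nM in this assay, at which 2 of the 2 values shown sit), so where compound 2 stands is known only to that extent.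

Compound 3 `C[C@@H]1CN(c2cccc3c2C[C@H](CN(C)[C@H]2CCCc4cccnc42)NC3)C[C@H](C)N1` differs from compound 2 at a single place: 3,5-dimethylpiperazin-1-yl in place of 4-cyclopropylpiperazin-1-yl on an aromatic carbon. Among the compounds with values here, no measured step covers an exchange of this kind, and the only step at hand gives no size at all. The expectation for compound 3 is accordingly no readable change, a number no higher from compound 2 to compound 3 (the limit leaves the size open), with the value again most likely reported as a limit. The estimate for compound 3 in this assay is 30000 nM, spanning 10000 nM to 100000 nM.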

Compound 3, half-maximal effective concentration: > 30000 nM
Compound 3: a limit, no number; the forecaster's own chance of this, stated with the estimate: 85%; the middle value sits exactly at the limit.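

In this assay compound 3 gives > 30000 nM, again a limit and not a number, so the step to it from compound 2 cannot be read in size. The compounds shown leave open how far compound 1, compound 2 and compound 3 each lie beyond that limit.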